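Two Ring Swaps on a Shared Amide Core, One Still Unmeasured

The source may report more compounds than this note shows. Statements on the series, on what has been measured and on what is new or still open speak of the compounds shown alone.

Of the compounds shown here, two that share a core have been tested in a functional assay on C6 cells (Rattus norvegicus) for cytotoxicity, read by MTT assay, with a stated time of 24 h, tested at 12 ug/mL; a higher number here means a weaker effect of the compound at the concentration tested, a lower number a stronger effect. Compound 1 `O=C(CSc1nnnn1-c1ccccc1)N/N=c1/scc(-c2ccc(Br)cc2)n1-c1ccccc1` gives 58.6%. Compound 2 `Cn1cnnc1SCC(=O)N/N=c1/scc(-c2ccccc2)n1-c1ccccc1` gives 79.6%, the highest of the two numbers and, against compound 1, a gap that lies beyond the scatter, so compound 2 shows the weaker effect.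

Compound 3 `O=C(CSc1nnnn1-c1ccccc1)N/N=c1/scc(-c2ccccc2)n1-c1ccccc1` has not yet been measured. It differs from compound 2 in one place: 1-phenyl-1H-tetrazol-5-yl in place of 4-methyl-4H-1,2,4-triazol-3-yl on a sulfur. For the measured compounds named here, no measured pair shows this change alone, so its effect is not known from the data. Compound 1 carries the same 1-phenyl-1H-tetrazol-5-yl group and gives 58.6% in this assay, which is the only hint available.

The step from compound 2 to compound 3 is therefore expected to be moderate and downward, a number 11.6 percentage points lower from compound 2 to compound 3 (beyond the scatter). Compound 3 is expected to come in at 68%, within a range from 52% to 84%.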

Compound 3, a percentage reported as activity, at one concentration (the size of the read-out at that concentration, not a potency): 47.1%
The estimate for compound 3 lay 20.9 percentage points above the measured number, outside the stated range (below it).
By their numbers in this assay, from the lowest: compound 3; then compound 1; then compound 2.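

In this assay, for the compounds shown here, a lower number means a stronger effect, so putting 1-phenyl-1H-tetrazol-5-yl in place of 4-methyl-4H-1,2,4-triazol-3-yl on the sulfur strengthens the effect, with a number 32.5 percentage points lower from compound 2 to compound 3 (beyond the scatter) as a large step that gives the first clean reading of this swap. The bromo group can now be read alone as well: hydrogen in its place on the aromatic carbon gives a number 11.5 percentage points lower from compound 1 to compound 3 (beyond the scatter) as a modest step, so here the compound without bromo shows the stronger effect. The data at hand offer no measurement that explains either step.

Whether the bromo step would look the same with 4-methyl-4H-1,2,4-triazol-3-yl on the sulfur remains open, as the compounds shown read it only with 1-phenyl-1H-tetrazol-5-yl. Also open, from the compounds shown here alone, is how a chloro group, an amine or a carboxylic acid in place of the bromo would change the number.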